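From Compound 1 to Compound 4 on a Carbonyl Carbon

This account rests on a few compounds, and the source may have more. Where it says the series, first, only, none or still open, it means among the compounds named here.

Of the compounds shown here, three have been measured in a functional assay on HepG2 cells (Homo sapiens) for cytotoxicity, read by ELISA, with stated times of 2 h and 48 h (on this read-out lower numbers stand for stronger inhibition and higher numbers for weaker inhibition), so far. Compound 1 (`C/C(=N/NC(=O)C(C#N)C(=S)S)c1ccc(NS(=O)(=O)c2ccc(C)cc2)cc1`) gives 5000 nM and sits at the low end of the set. Compound 3 (`C/C(=N\NC(=O)c1sc(N)c(C#N)c1N)c1ccc(NS(=O)(=O)c2ccc(C)cc2)cc1`) gives 5800 nM and lies within the scatter of compound 1, so the two cannot be told apart. Compound 2 (`C/C(=N/n1c(N)cc(N)c(C#N)c1=O)c1ccc(NS(=O)(=O)c2ccccc2)cc1`) gives 11500 nM as a higher number, beyond the scatter of compound 1.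

Compound 4 (`C/C(=N/NC(=O)c1sc2c(c1N)CCCC2)c1ccc(NS(=O)(=O)c2ccc(C)cc2)cc1`) has not yet been measured. It departs from compound 1 at one place, on a carbonyl carbon (a group of 10 heavy atoms (8 carbon, 1 nitrogen, 1 sulfur; one five-membered aromatic ring with 1 hetero atom, one six-membered non-aromatic ring of carbon only) in place of a group of 6 heavy atoms (3 carbon, 1 nitrogen, 2 sulfur; no ring), on a carbonyl carbon). Going by the values given here, no two measured compounds differ in only one place, so nothing measured isolates a change of this kind. Among the compounds with values here, the only guide is the narrow measured span, with compound 1 at 5000 nM and compound 2 at 11500 nM as its two ends. On that basis, no step beyond the scatter is expected in this assay, with only a slight lean towards a higher number. The estimated step of a 1.2-fold higher number from compound 1 to compound 4 (0.08 log units; within the scatter) is therefore expected to stay small. For compound 4 the estimated value is 6000 nM with an expected range from 2500 nM to 14000 nM when the measurement is made.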

Compound 4, half-maximal inhibitory concentration: 20000 nM
The estimate for compound 4 lay 3.3-fold (0.52 log units) below the measured number, and the stated range ends below it.
By their numbers in this assay, from the lowest: compounds 1, 3, 2 and 4 (each within the scatter of the next, the first and the last beyond it).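

In this assay, going by these compounds alone, the exchange on a carbonyl carbon whose other neighbour is an amide-type nitrogen gives a 4.0-fold higher number from compound 1 to compound 4 (0.60 log units; beyond the scatter) and is the only step in the set that isolates a single change, showing that the read-out responds to what is carried at this position. The group that enters and the group that leaves have the same counts of hydrogen-bond donors and acceptors and no net charge, so these counts do not separate them; they differ instead in heavy-atom count, in the one five-membered aromatic ring and one six-membered non-aromatic ring of the entering group, and in the double and triple bonds of the leaving group. The data at hand offer no explanation for the step.

With all of these features exchanged at once, the step cannot be assigned to the rings, to the larger size of the entering group or to the loss of the nitrile. As far as these compounds go, it also remains open how a much smaller substituent at the same place, such as a methyl group or a simple amine, would read out.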